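Swapping the Distal Ring for a Trifluoromethylpyridyl Group

The source may hold more compounds than are shown below. What is called first, only, known or untested is meant among the compounds shown, and "the series" means these compounds.

Of the compounds shown here, three sharing one core have been tested in an assay on a protein complex for inhibition of ubiquitin carboxyl-terminal hydrolase 1/WD repeat-containing protein 48 (Homo sapiens), read by fluorescence; a lower number here means a stronger inhibitor, a higher number a weaker inhibitor. Compound 1 `FC(F)(F)c1ccccc1-c1nc(NCc2ccc(Cl)cc2)c2ccccc2n1` gives 4800 nM, compound 2 `N#Cc1ccc(CNc2nc(-c3ccccc3C(F)(F)F)nc3ccccc23)cc1` gives 5700 nM, and compound 3 `FC(F)(F)c1ccccc1-c1nc(NCc2ccc(-c3ccc(Cl)cc3)cc2)c2ccccc2n1` gives 3600 nM. Compound 3 stands at the lowest of these three numbers, yet every gap to it is small: a 1.3-fold lower number from compound 1 to compound 3 (0.12 log units; within the scatter), a 1.6-fold lower number from compound 2 to compound 3 (0.20 log units; within the scatter), and likewise a 1.2-fold higher number from compound 1 to compound 2 (0.07 log units; within the scatter). Compound 4 `FC(F)(F)c1cc(-c2ccc(CNc3nc(-c4ccccc4C(F)(F)F)nc4ccccc34)cc2)ccn1` differs from compound 3 in one place: 2-(trifluoromethyl)pyridin-4-yl in place of 4-chlorophenyl on an aromatic carbon. All measured steps that altered this same position stayed within the scatter, so the expected step is a 1.1-fold lower number from compound 3 to compound 4 (0.05 log units; within the scatter), with no change beyond the scatter. Compound 4 is therefore estimated at 3200 nM, within a range from 1200 nM to 8500 nM.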

Compound 4, half-maximal inhibitory concentration: 4900 nM
Beside the measured number, compound 4's estimate is 1.5-fold (0.19 log units) below it; low and high end bracket the measured number.
By their numbers in this assay, from the lowest: compounds 3, 1, 4 and 2 (each within the scatter of the next).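

At this position, on an aromatic carbon para to a large group, 2-(trifluoromethyl)pyridin-4-yl brings a ring hetero atom and still leaves the result within the scatter of every other group: a 1.4-fold higher number from compound 3 to compound 4 (0.13 log units; within the scatter), a 1.2-fold lower number from compound 2 to compound 4 (0.07 log units; within the scatter) and a 1.0-fold higher number from compound 1 to compound 4 (0.01 log units; within the scatter). Chloro, cyano, 4-chlorophenyl and this ring thus cannot be told apart in this assay. Nothing available bears on why these numbers stay so close. Still open, as far as these compounds go, is whether an amine or a carboxylic acid at this position would produce a step beyond the scatter.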